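The compounds below may be only part of what the source reports. "The series", "measured", "known", "first", "only" and "open" are said of these compounds alone.

Measured in a functional assay on HepG2 cells (Homo sapiens) for antiproliferative activity, with a stated time of 72 h; a higher number here means that more compound is needed for the effect, a lower number that less compound is needed:
- Compound 1 `COc1ccc(-c2cc(=O)c3c(OC)cc(OC)cc3[nH]2)cc1`: > 31100 nM
- Compound 2 `COc1ccc(-c2cc(=O)c3c(OC)cc(OC)cc3n2Cc2ccccc2)cc1`: > 17300 nM
- Compound 3 `COc1ccc(-c2cc(=O)c3c(OC)cc(OC)cc3n2S(=O)(=O)c2ccc(C#N)cc2)cc1`: > 17200 nM

All three entries are limits of the assay and not numbers, so the series offers no exact value to build on. Compound 3 stands only at its limit of > 17200 nM. The same is true of the other two compounds, each at its own limit.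

Compound 4 `COc1ccc(-c2cc(=O)c3c(OC)cc(OC)cc3n2S(=O)(=O)c2ccc(Cl)cc2)cc1` differs from compound 3 in a single group, with chloro in place of cyano on an aromatic carbon, para to a large group (chloro in place of cyano on an aromatic carbon).

Within the data shown here, no measured step shows this exchange directly. The available steps all concern the group on the aromatic nitrogen: a step that the two limits leave unreadable from compound 1 to compound 2, a step that the two limits leave unreadable from compound 1 to compound 3 and a step that the two limits leave unreadable from compound 2 to compound 3. None of them has a readable size, and none gives a direction for the new change.

With so little to go on, no step beyond the usual scatter is expected in this assay, and another limit is the likeliest report. The expected change is a step that the limit leaves unreadable from compound 3 to compound 4. The estimate for compound 4 is 20000 nM, with an expected range from 6000 nM to 40000 nM.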

Compound 4, half-maximal effective concentration: > 34400 nM
Compound 4: a limit, no number (the forecaster's own chance of this, stated with the estimate: 75%); middle value at least 1.7-fold (0.23 log units) from the limit.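

In this assay compound 4 gives > 34400 nM, which is a limit and not a number. Its steps from compound 1, compound 2 and compound 3 cannot be read, and all four entries are limits. The compounds shown leave open at what concentration, if any, each one would reach the half-maximal effect.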